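Changing One Group on Compound 3

The source may hold more compounds than are shown below. What is called first, only, known or untested is meant among the compounds shown, and "the series" means these compounds.

Measured compounds:
Compound 1 `Nc1ccc(CNC(=O)Nc2ccc(CN3C(=O)c4ccccc4C3=O)cc2)cn1`: 100 nM
Compound 2 `O=C(Nc1ccc(CN2Cc3ccccc3C2=O)cc1)N1CCC(c2cccnc2)CC1`: 1030 nM
Compound 3 `C[C@@H](c1ccc(NC(=O)N2CC(c3cccnc3)C2)cc1)N1Cc2ccccc2C1=O`: 1.5 nM

In a functional assay on A2780 cells (Homo sapiens) for antiproliferative activity, read by CellTiter-Glo, with a stated time of 72 h (a lower number here means a stronger inhibitor, a higher number a weaker inhibitor), compound 3 gives 1.5 nM, the lowest of the three numbers and so the strongest inhibitor measured here. Compound 1 gives 100 nM and compound 2 gives 1030 nM, and both lie beyond the scatter from compound 3.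

The next compound to be tested is compound 4 `C[C@H](NC(=O)[C@@H]1CCCN1C)c1ccc(NC(=O)N2CC(c3cccnc3)C2)cc1`. It keeps most of compound 3 and changes one group: a group of 9 heavy atoms (6 carbon, 2 nitrogen, 1 oxygen; one five-membered non-aromatic ring with 1 hetero atom) in place of a group of 10 heavy atoms (8 carbon, 1 nitrogen, 1 oxygen; one five-membered non-aromatic ring with 1 hetero atom, one six-membered aromatic ring of carbon only), on a saturated chain carbon bound to an aromatic carbon and a saturated chain carbon. The incoming group is ((1-methylpyrrolidin-2-yl)carbonyl)amino, and it sits on a saturated chain carbon bound to an aromatic carbon and a saturated chain carbon. The group it replaces carries a six-membered aromatic ring of carbon only, and the new group has no such ring.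

Among the measured compounds shown here, no two measured compounds differ in only one place, so no measured step guides this forecast, and it remains a judgement. Compound 3 already stands at 1.5 nM, the low end of the numbers seen so far, so a rise looks more likely than a further fall. The expected step is a 10-fold higher number from compound 3 to compound 4 (1.00 log units; beyond the scatter), probably beyond the scatter and towards a weaker inhibitor. Compound 4 is estimated at 15 nM, with an expected range of 2 nM to 100 nM.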

Compound 4, half-maximal inhibitory concentration: 5.7 nM
The estimate for compound 4 lay 2.6-fold (0.42 log units) above the measured number; the measured number falls inside the stated range.
By their numbers in this assay, from the lowest: compound 3; then compound 4; then compound 1; then compound 2.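

In this assay, a 3.8-fold higher number from compound 3 to compound 4 (0.58 log units; beyond the scatter) is modest, though beyond the scatter, and it comes from placing ((1-methylpyrrolidin-2-yl)carbonyl)amino on a saturated chain carbon bound to an aromatic carbon and a saturated chain carbon. Among the compounds shown here, this single change gives the first direct reading at this position, and it shows that the six-membered aromatic ring of carbon only is not needed for a low number here: compound 4, which has no such ring, gives 5.7 nM. The change also adds a hydrogen-bond donor and a defined stereocentre, and nothing available shows which difference accounts for the higher number.

The compounds shown leave open how much of the incoming group is needed, since a plain acetylamino group or a simple amine on the same carbon would test whether the ring matters at all. They also leave open the role of the methyl on the pyrrolidine nitrogen and of the defined stereocentre, which the unmethylated pyrrolidine and the mirror-image form of the group could each address.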